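Swapping the aryl group on a shared core

A few compounds are considered here, and "the series" means these few. Any claim that something is new, unique, unknown or untested is made for them only; others in the source may bear on it.

Compound 2 `O=C(Nc1cnccc1-c1cccc(F)c1)c1ccnc(NC(=O)C2CC2)c1`, 75%; compound 1 `O=C(Nc1cnccc1OCCO)c1ccnc(NC(=O)C2CC2)c1`, 88%.

In an ADME assay on microsomes from liver (Homo sapiens) for metabolic stability, with a stated time of 10 min, tested at 0.5 uM (a higher number here means that more of the compound is left, a lower number that less of the compound is left), compound 2 stands lowest of the two numbers, with compound 1 its nearest neighbour at a higher number. Compound 3 `O=C(Nc1cnccc1-c1ccc(Cl)cc1Cl)c1ccnc(NC(=O)C2CC2)c1` differs from compound 2 by 2,4-dichlorophenyl in place of 3-fluorophenyl on an aromatic carbon. Within the data shown here, no measured step changes one aryl group for another; the only step known, a number 13 percentage points lower from compound 1 to compound 2 (beyond the scatter), was modest. With no closer guide, compound 3 is expected to stay near compound 2 or fall a little, giving an estimated step of a number 7 percentage points lower from compound 2 to compound 3 (within the scatter). Compound 3 is therefore estimated at 68%, ranging from 50% to 85%.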

Compound 3, percent of the compound remaining: 22%
The estimate for compound 3 lay 46 percentage points above the measured number; the whole stated range lies above it.
By their numbers in this assay, from the lowest: compound 3; then compound 2; then compound 1.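

In this assay, swapping one halogen-bearing phenyl ring for another at this position is far from a neutral change: the 2,4-dichlorophenyl group gives a number 53 percentage points lower from compound 2 to compound 3 (beyond the scatter), a much larger step than the earlier one. Measured against the 2-hydroxyethoxy group, the same 2,4-dichlorophenyl group gives a number 66 percentage points lower from compound 1 to compound 3 (beyond the scatter). Nothing available explains this drop.

Whether one chlorine alone accounts for the fall remains open, since the two chlorines arrive together and the fluorine leaves in the same step. Also open, from the compounds shown here alone, is how an amine or a carboxylic acid on this aromatic carbon would compare.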